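Removing a 3,4-dichlorobenzyl group from compound 2

The source may hold more compounds than are shown below. What is called first, only, known or untested is meant among the compounds shown, and "the series" means these compounds.

Measured in a functional assay on CNE2Z cells (Homo sapiens) for inhibition, read by MTT assay, with a stated time of 72 h (on this read-out lower numbers stand for stronger inhibition and higher numbers for weaker inhibition), so far
- compound 1 `C=CCc1ccc(OCc2ccc(Cl)cc2Cl)c(-c2ccc(O)c(CC=C)c2)c1` with 24200 nM as its value
- compound 2 `C=CCc1ccc(OCc2ccc(Cl)c(Cl)c2)c(-c2ccc(OCc3ccc(Cl)c(Cl)c3)c(CC=C)c2)c1` with > 50000 nM as a limit

Compound 2 has no number, and in this assay compound 2 reads > 50000 nM as a limit of the assay. Compound 3 `C=CCc1ccc(OCc2ccc(Cl)c(Cl)c2)c(-c2ccc(O)c(CC=C)c2)c1` follows from compound 2 by one change hydrogen in place of 3,4-dichlorobenzyl on an oxygen on an aromatic ring that turns (3,4-dichlorobenzyl)oxy to hydroxy. Among the compounds with values here, no measured step shows this change. Compound 1, which also carries a hydroxy, gives 24200 nM and so points to stronger inhibition. The expected move beyond the scatter is the estimated at least 2.2-fold lower number from compound 2 to compound 3 (0.35 log units; beyond the scatter) toward lower numbers. For compound 3 the estimated value is 22000 nM with an expected range of 11000 nM to 42000 nM around it.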

Compound 3, half-maximal inhibitory concentration: 14200 nM
Estimate against measurement, compound 3: 1.5-fold (0.19 log units) above; the range from low to high includes it.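

In this assay, within the data shown here, replacing the 3,4-dichlorobenzyl group on this oxygen with hydrogen gives a step that no earlier pair showed: an at least 3.5-fold lower number from compound 2 to compound 3 (0.54 log units; beyond the scatter), beyond the scatter. Compound 2 stands only as a limit of the assay: the limit of > 50000 nM in this assay, at which 1 of the 3 values shown sits. The change from 2,4-dichlorophenyl to 3,4-dichlorophenyl gives a 1.7-fold lower number from compound 1 to compound 3 (0.23 log units; within the scatter), within the scatter, so it does not separate the two compounds. As far as these compounds go, whether a methoxy group or an amine in place of the hydroxy would read like compound 3 stays open. From the compounds shown here alone, the full size of the step from compound 2 also stays open.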